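This account rests on a few compounds, and the source may have more. Where it says the series, first, only, none or still open, it means among the compounds named here.

Measured compounds:
Compound 1 `Nc1ncnc2c1c(-c1cnc3[nH]ccc3c1)nn2CC(=O)NO` gives in a functional assay on CNE-2 cells (Homo sapiens) for inhibition, read by MTT assay, with a stated time of 72 h (on this read-out lower numbers stand for stronger inhibition and higher numbers for weaker inhibition), the value > 150000 nM, which is a limit of the assay and not a number.
Compound 3 `Nc1ncnc2c1c(-c1cnc3[nH]ccc3c1)nn2CCC(=O)NO` gives in this assay the value > 150000 nM, again a limit rather than a number.
Compound 2 `Nc1nc2cc(-c3nn(CCCCC(=O)NO)c4ncnc(N)c34)ccc2o1` gives in this assay the value > 50000 nM, also a limit and not a number.

Compound 1 and compound 3 differ in one place: (hydroxycarbamoyl)methyl in place of hydroxycarbamoyl on a saturated chain carbon bound to an aromatic nitrogen. The step that the two limits leave unreadable from compound 1 to compound 3 cannot be read, since both ends sit at the limit of > 150000 nM in this assay, at which 2 of the 3 values shown sit. Compound 2 rests at a different limit, (the limit of > 50000 nM in this assay, at which 1 of the 3 values shown sits), and how its core differs from the core of compound 1 is not broken down here.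

The unmeasured compound 4 `Nc1nc2cc(-c3nn(CCCCCC(=O)NO)c4ncnc(N)c34)ccc2o1` is made from compound 2 by the same kind of change: (hydroxycarbamoyl)methyl in place of hydroxycarbamoyl on a saturated chain carbon, four bonds along the chain from an aromatic nitrogen. The surroundings differ from the first pair, where the change sits on a saturated chain carbon bound to an aromatic nitrogen, whereas here it sits four bonds along the chain from an aromatic nitrogen. Compared with the step from compound 1 to compound 3, the step from compound 2 to compound 4 is expected to be a step that the limit leaves unreadable from compound 2 to compound 4, an expectation resting on compound 2 showing only a limit, > 50000 nM, and on compound 1 and compound 3 both sitting at a limit. Compound 4 is therefore estimated at 100000 nM, with a likely range from 30000 nM to 300000 nM, and most probably the assay would again report only a limit.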

Compound 4, half-maximal inhibitory concentration: 37600 nM
Compound 4: middle estimate off by 2.7-fold (0.42 log units), on the high side, and the stated range covers the measured number.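

In this assay, (hydroxycarbamoyl)methyl in place of hydroxycarbamoyl on the core of compound 2 gives an at least 1.3-fold lower number from compound 2 to compound 4 (0.12 log units; that floor lies within the scatter), and compound 4 is the only compound shown that reads as a number rather than a limit. As far as these compounds go, compound 2 gives > 50000 nM, which is a limit of the assay and not a number, so the true size of this step stays unknown and its floor, lying within the scatter, does not by itself establish any real change. The same replacement on the core of compound 1 cannot be read, so the compounds shown do not tell whether the change acts alike on the two cores: the limit of > 150000 nM in this assay, at which 2 of the 4 values shown sit.

The compounds shown leave open whether a longer chain than that of compound 4 would move the number further on the core of compound 2, and whether a chain of the same length would give a readable number on the core of compound 1. From the compounds shown here alone, they also leave open what a carboxylic acid or a primary amide in place of the hydroxycarbamoyl end would give in this assay, so the part that end plays in the number of compound 4 remains unknown.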